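Replacing thiophen-3-yl with 4-acetylphenyl on the shared core

The source may report more compounds than this note shows. Statements on the series, on what has been measured and on what is new or still open speak of the compounds shown alone.

Compound 3 `c1cn2cc(-c3ccsc3)nc(-c3ccc4ncn(C5CCCCC5)c4c3)c2n1` gives 19.9% in a functional assay on PC-3 cells (Homo sapiens) for inhibition, read by sulforhodamine B assay, with a stated time of 48 h, tested at 10 uM (on this read-out higher numbers stand for more inhibition at the one concentration tested (going by the name of the read-out) and lower numbers for less inhibition), the second highest of three numbers; compound 1 `Brc1cn2ccnc2c(-c2ccc3ncn(C4CCCCC4)c3c2)n1` gives 17.2%, within the scatter of compound 3, while compound 2 `c1ccc(-c2cn3ccnc3c(-c3ccc4ncn(C5CCCCC5)c4c3)n2)cc1` gives 92%, far above both. Compound 4 `CC(=O)c1ccc(-c2cn3ccnc3c(-c3ccc4ncn(C5CCCCC5)c4c3)n2)cc1` differs from compound 3 by 4-acetylphenyl in place of thiophen-3-yl on an aromatic carbon. The step bearing on this is a number 72.1 percentage points lower from compound 2 to compound 3 (beyond the scatter), a large loss when thiophen-3-yl replaced phenyl; a number 74.8 percentage points higher from compound 1 to compound 2 (beyond the scatter) shows the same gain from the other side, and a number 2.7 percentage points higher from compound 1 to compound 3 (within the scatter) was flat. Returning to a phenyl ring, now carrying an acetyl group, is expected to give a large rise in this assay, a number 55.1 percentage points higher from compound 3 to compound 4 (beyond the scatter); the acetyl group itself is untested here, so the range is wide. Compound 4 is estimated at 75%, between 40% and 95%.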

Compound 4, a percentage reported as inhibition, at one concentration (the size of the read-out at that concentration, not a potency): 17.9%
Beside the measured number, compound 4's estimate is 57.1 percentage points above it; measured number outside the range, below it.
By their numbers in this assay, from the lowest: compounds 1, 4 and 3 (each within the scatter of the next); then compound 2.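

In this assay the acetyl group on the phenyl ring removes the gain of the plain phenyl, with a number 74.1 percentage points lower from compound 2 to compound 4 (beyond the scatter) as the step, so an aromatic six-membered ring at this position is not enough by itself. 4-Acetylphenyl reads level with thiophen-3-yl and with bromo, as shown by a number 2 percentage points lower from compound 3 to compound 4 (within the scatter) and by a number 0.7 percentage points higher from compound 1 to compound 4 (within the scatter) as well, which leaves compound 2 alone beyond the scatter of the others. Nothing measured here accounts for this loss.

Open, on these data alone, is whether the loss belongs to the acetyl group specifically or to any group on the phenyl ring. A methoxy group, an amine or a carboxylic acid in place of the acetyl would separate these.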